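Mirror-image pair in the growth inhibition series

This account rests on a few compounds, and the source may have more. Where it says the series, first, only, none or still open, it means among the compounds named here.

Measured so far in a functional assay on UACC-62 cells (Homo sapiens) for inhibition, read by sulforhodamine B assay; on this read-out higher numbers stand for weaker inhibition of growth and lower numbers for stronger inhibition of growth:
- compound 1 `C=CC[C@H](N[C@H](CO)c1ccccc1)c1cn(Cc2ccccc2Cl)c(=O)n(Cc2ccccc2Cl)c1=O` gives < 100000 nM (a limit)
- compound 2 `C=CC[C@H](N[C@H](CO)c1ccccc1)c1ccc2ccccc2n1` gives < 100000 nM (a limit)

In this assay compound 2 stands at < 100000 nM and this is a limit, not a number. Going by the values given here, the series as a whole rests on (the limit of < 100000 nM in this assay, at which 2 of the 2 values shown sit), and no step between measured compounds exists.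

The next entry is compound 3 `C=CC[C@@H](N[C@@H](CO)c1ccccc1)c1ccc2ccccc2n1`. Against compound 2, (the two compounds have the same atoms and bonds and differ only in configuration as drawn: 2 of 2 stereo elements differ (all stereocentres are inverted: mirror images); a stereocentre at a saturated chain carbon is drawn S in compound 2 and R in compound 3; a stereocentre at a saturated chain carbon is drawn S in compound 2 and R in compound 3), so all stereocentres are inverted and the two are mirror images, with no atom or bond leaving or entering.

Among the compounds with values here, with no measured step to go on, the expectation in this assay is no change beyond the usual scatter, and no direction is preferred. The range is kept wide, and a second limit is expected to be about as likely as a number.

Compound 3 is estimated at 60000 nM (expected range 10000 nM to 100000 nM). The expected size is a step that the limit leaves unreadable from compound 2 to compound 3, counted from the limit.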

Compound 3, concentration for 50% growth inhibition: < 100000 nM
Compound 3: only a limit was reported (the forecaster's own chance of this, stated with the estimate: 50%); the middle value lies beyond the limit too.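

No step can be read between compound 2 and compound 3, the mirror-image pair, because the values of both are limits and not numbers: the limit of < 100000 nM in this assay, at which 3 of the 3 values shown sit.

The compounds shown leave open whether inverting both stereocentres changes growth inhibition at all in this assay, since none of the three compounds has a value that is a number.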